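The source may report more compounds than this note shows. Statements on the series, on what has been measured and on what is new or still open speak of the compounds shown alone.

Compound 1, with structure `CS(=O)(=O)c1ccc(OCc2ccc(F)cc2F)c(C2=C(c3cccc(C(=O)O)c3)CCC2)c1`, gives 15.9 nM in an assay on isolated protein for inhibition of prostaglandin E2 receptor EP1 subtype (Homo sapiens) (a lower number here means a stronger inhibitor, a higher number a weaker inhibitor), the highest of the three numbers measured. Compound 2, `O=C(O)c1cccc(C2=C(c3cc(Br)ccc3OCc3ccc(F)cc3F)CCC2)c1`, gives 5.01 nM, and compound 3, `O=C(O)c1cccc(C2=C(c3cc(Cl)ccc3OCc3ccccc3)CCC2)c1`, gives 5.01 nM. For the measured compounds named here, the one single-place step known, a 3.2-fold lower number from compound 1 to compound 2 (0.50 log units; beyond the scatter), concerns a different part of the shared core. Compound 4, `CS(=O)(=O)c1ccc(OCc2ccc(F)cc2)c(C2=C(c3cccc(C(=O)O)c3)CCC2)c1`, differs from compound 1 only in that (hydrogen in place of fluoro on an aromatic carbon). Going by the values given here, no measured step isolates this change; compound 2 and compound 3 carry different benzyl groups yet give the same number, which suggests the change counts for little. The expected step is therefore a 1.3-fold higher number from compound 1 to compound 4 (0.10 log units; within the scatter), within the scatter. Compound 4 is estimated at 20 nM, in the range 8 nM to 50 nM.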

Compound 4, half-maximal inhibitory concentration: 79.4 nM
Estimate against measurement, compound 4: 4.0-fold (0.60 log units) below, and the stated range ends below it.
By their numbers in this assay, from the lowest: compounds 2 and 3 (each within the scatter of the next); then compound 1; then compound 4.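

In this assay, the step from 2,4-difluorobenzyl to 4-fluorobenzyl gives a 5.0-fold higher number from compound 1 to compound 4 (0.70 log units; beyond the scatter). This shows that the fluoro group ortho to a large group counts at this position, although the change removes only one heavy atom. Nothing available explains why the number rises. As far as these compounds go, whether a methyl or methoxy group at this position would match fluoro or hydrogen remains open. So does whether the same change would have a similar effect with bromo in place of methylsulfonyl, as in compound 2.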